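Replacing the thiazolyl group of compound 3

This account rests on a few compounds, and the source may have more. Where it says the series, first, only, none or still open, it means among the compounds named here.

Measured so far in a physicochemical assay for solubility; on this read-out lower numbers stand for lower solubility and higher numbers for higher solubility:
- Compound 1 `O=S(=O)(Nc1ncccn1)c1ccc2c(c1)OCC[C@@H]2c1ccc(C(F)(F)F)cc1-c1ccc(F)nc1`: 408000 nM
- Compound 2 `O=S(=O)(Nc1nccs1)c1ccc2c(c1)OCC[C@@H]2c1ccc(C(F)(F)F)cc1-c1ccc(F)cn1`: 7000 nM
- Compound 3 `O=S(=O)(Nc1nccs1)c1ccc2c(c1)OCC[C@@H]2c1ccc(C(F)(F)F)cc1-c1nccs1`: 15000 nM

Compound 3 stands in the middle of these three numbers, well under compound 1 and a modest distance over compound 2. The next molecule, compound 4 `O=S(=O)(Nc1nccs1)c1ccc2c(c1)OCC[C@@H]2c1ccc(C(F)(F)F)cc1-c1ccc(F)nc1`, has 6-fluoropyridin-3-yl in place of 1,3-thiazol-2-yl on an aromatic carbon, ortho to a large group and meta to a trifluoromethyl group. The count of that change is 6-fluoropyridin-3-yl in place of 1,3-thiazol-2-yl on an aromatic carbon here.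

Going by the values given here, only one measured step bears directly on this place. It is a 2.1-fold higher number from compound 2 to compound 3 (0.33 log units; beyond the scatter) when 1,3-thiazol-2-yl replaced 5-fluoropyridin-2-yl, a modest move just beyond the scatter. Read backwards, it points to a slightly lower number when a fluoropyridinyl group enters, though compound 4 carries a different isomer from compound 2. Among the compounds with values here, the 6-fluoropyridin-3-yl group itself appears in compound 1 at 408000 nM in a molecule that also differs elsewhere, and no measured step isolates that group's share.

In this assay only a small downward move, within the scatter, is therefore expected, and the estimated change is a 1.7-fold lower number from compound 3 to compound 4 (0.22 log units; within the scatter) in size. For compound 4 the estimate is 9000 nM with an expected range from 3000 nM to 30000 nM as the likely span.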

Compound 4, solubility: 21000 nM
Beside the measured number, compound 4's estimate is 2.3-fold (0.37 log units) below it, and the stated range covers the measured number.
By their numbers in this assay, from the lowest: compound 2; then compounds 3 and 4 (each within the scatter of the next); then compound 1.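

In this assay, putting 6-fluoropyridin-3-yl in place of 1,3-thiazol-2-yl on this aromatic carbon gives a 1.4-fold higher number from compound 3 to compound 4 (0.15 log units; within the scatter) and so leaves the read-out unresolved: a five-membered and a six-membered aromatic ring cannot be told apart here. The two fluoropyridine isomers can be told apart, since 6-fluoropyridin-3-yl in place of 5-fluoropyridin-2-yl gives a 3.0-fold higher number from compound 2 to compound 4 (0.48 log units; beyond the scatter) as a modest step, which shows that the arrangement of atoms in the ring can matter even when the ring's atom count stays the same. A much larger step lies at a different place, the sulfonamide nitrogen, where 1,3-thiazol-2-yl in place of pyrimidin-2-yl gives a 19-fold lower number from compound 1 to compound 4 (1.29 log units; beyond the scatter) as a change that exceeds every step seen so far at the aromatic carbon.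

Going by these compounds, it remains open whether a group without an aromatic ring at this carbon, such as an amine, a carboxylic acid or a longer chain, would shift the number more, and whether the sulfonamide step keeps its size with other rings on the aromatic carbon. Nothing available gives a reason for the size of any of these steps.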